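A few compounds are considered here, and "the series" means these few. Any claim that something is new, unique, unknown or untested is made for them only; others in the source may bear on it.

Working notes on the carboxamide series. In an assay on cells for inhibition of MAP kinase-interacting serine/threonine-protein kinase 1 (Homo sapiens), read by mobility shift assay, with stated times of 10 min and 60 min, in the presence of a further agent that is not named here (a higher number here means a weaker inhibitor, a lower number a stronger inhibitor), compound 1 `NC(=O)c1ccc(-c2cccnc2)cc1OC1CCNCC1` gives 1100 nM and compound 2 `COc1cncc(-c2ccc(C(N)=O)cc2)c1` gives 3000 nM. Compound 3 `COc1cc(C(N)=O)ccc1-c1cccnc1` gives 29300 nM in this assay, the highest number of the three; its separation from compound 2, and the still wider one from compound 1, both lie beyond the scatter, so compound 3 counts as the weakest inhibitor measured so far. The shared core carries a carbamoyl group and a pyridinyl group on a benzene ring, and the three measured compounds differ only in the substituent placed on one or the other ring.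

Compound 4 `NC(=O)c1ccc(-c2cccnc2)cc1` has not yet been measured in this assay. It differs from compound 3 by hydrogen in place of methoxy on an aromatic carbon. Going by the values given here, no measured pair shows this exact change, so the size of the step is open. Compound 2, which carries its methoxy on the pyridine ring instead, gives 3000 nM. Compound 1 carries a larger group at the same place as the methoxy of compound 3; in this assay compound 1 gives 1100 nM. Both sit well under compound 3, which suggests the bare core need not be weak. The step from compound 3 to compound 4 is expected to be a 5.9-fold lower number from compound 3 to compound 4 (0.77 log units; beyond the scatter), toward a lower number. Compound 4 is estimated at 5000 nM, within 1500 nM to 18000 nM.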

Compound 4, half-maximal inhibitory concentration: 8800 nM
Compound 4: middle estimate off by 1.8-fold (0.25 log units), on the low side; the range from low to high includes it.
By their numbers in this assay, from the lowest: compound 1; then compound 2; then compound 4; then compound 3.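

In this assay, on the aromatic carbon ortho to a group of 6 heavy atoms and meta to a carbamoyl group, the two substituents shown pull in opposite directions relative to hydrogen: replacing methoxy with hydrogen lowers the number (a 3.3-fold lower number from compound 3 to compound 4 (0.52 log units; beyond the scatter)), whereas replacing (piperidin-4-yl)oxy with hydrogen raises it (an 8.0-fold higher number from compound 1 to compound 4 (0.90 log units; beyond the scatter)). The same exchange of methoxy for hydrogen also raises the number when the methoxy sits on the other ring (a 2.9-fold higher number from compound 2 to compound 4 (0.47 log units; beyond the scatter)), so the direction of this change depends on where it is made. Nothing measured here accounts for these opposite directions.

The compounds shown leave open whether the step at this carbon follows the amine of the (piperidin-4-yl)oxy group or its ring, which a 2-aminoethoxy chain and a cyclohexyloxy group at the same place would separate. As far as these compounds go, how far the gain from methoxy on the other ring extends is also open, and an amine, a hydroxy group or a longer alkoxy chain there would test it.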